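This account rests on a few compounds, and the source may have more. Where it says the series, first, only, none or still open, it means among the compounds named here.

Measured so far in a toxicity assay on L02 cells (Homo sapiens) for cytotoxicity, read by MTT assay, with a stated time of 24 h; a lower number here means that less compound is tolerated, a higher number that more compound is tolerated:
- compound 1 `CCCCS(=O)(=O)Oc1ccc(/C=C/C(=O)Nc2cccc(C)c2)cc1OC` gives 33600 nM
- compound 2 `CCCCS(=O)(=O)Oc1ccc(/C=C/C(=O)Nc2ccc(Cl)cc2)cc1OC` gives 81200 nM
- compound 3 `CCCCS(=O)(=O)Oc1ccc(/C=C/C(=O)OCC)cc1OC` is still to be measured

Compound 1 holds the lower of the two numbers. Going to compound 3 puts ethoxy in place of (3-methylphenyl)amino on a carbonyl carbon. For the measured compounds named here, the only measured step bearing on this (a 2.4-fold higher number from compound 1 to compound 2 (0.38 log units; beyond the scatter)) is modest and keeps a ring on the amide-type nitrogen, so it is a loose guide. Compound 1 at 33600 nM is the low end of the pair, so a modest move to a higher number is expected in this assay rather than a lower one. The expected change is of similar size (a 2.1-fold higher number from compound 1 to compound 3 (0.32 log units; beyond the scatter)). The estimate for compound 3 is 70000 nM (expected range 25000 nM to 200000 nM).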

Compound 3, half-maximal cytotoxic concentration: 14400 nM
For compound 3 the middle estimate is 4.9-fold (0.69 log units) above the measured one; measured number outside the range, below it.
By their numbers in this assay, from the lowest: compound 3; then compound 1; then compound 2.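

In this assay, ethoxy on the carbonyl carbon gives a lower number than either ring-bearing amino group (a 2.3-fold lower number from compound 1 to compound 3 (0.37 log units; beyond the scatter); a 5.6-fold lower number from compound 2 to compound 3 (0.75 log units; beyond the scatter)). For the compounds shown here, compound 3 is therefore the least tolerated of the three, and changing this group as a whole can lower the number, whereas the only earlier step, between the two ring-bearing groups, raised it. Nothing measured here explains this direction.

The compounds shown do not separate loss of the ring from replacement of the amide nitrogen by oxygen. Ethylamino or phenoxy on the same carbonyl carbon would separate the two.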